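Swapping the nitro-bearing aryl group of compound 3

This account rests on a few compounds, and the source may have more. Where it says the series, first, only, none or still open, it means among the compounds named here.

Three analogues sharing one core have been measured in a functional assay on CCRF-CEM cells (Homo sapiens) for antiproliferative activity; on this read-out lower numbers stand for stronger inhibition and higher numbers for weaker inhibition. Compound 1 `COc1cc(C(=O)c2sc(-c3ccc(Cl)c(Cl)c3)cc2N)cc(OC)c1OC` gives 290 nM, compound 2 `COc1cc(C(=O)c2sc(-c3ccc(C(F)(F)F)cc3)cc2N)cc(OC)c1OC` gives 270 nM, and compound 3 `COc1cc(C(=O)c2sc(-c3ccc([N+](=O)[O-])cc3)cc2N)cc(OC)c1OC` gives 99 nM, the lowest of the three numbers. The steps of a 2.9-fold lower number from compound 1 to compound 3 (0.47 log units; beyond the scatter) and a 2.7-fold lower number from compound 2 to compound 3 (0.44 log units; beyond the scatter) both lead to compound 3, whereas a 1.1-fold lower number from compound 1 to compound 2 (0.03 log units; within the scatter) stays within the scatter. Compound 4 `COc1ccc(-c2cc(N)c(C(=O)c3cc(OC)c(OC)c(OC)c3)s2)cc1OC` differs from compound 3 by a single exchange: 3,4-dimethoxyphenyl in place of 4-nitrophenyl on an aromatic carbon. Going by the values given here, no measured step covers a methoxy-bearing aryl group, but the two measured steps towards compound 3 point the same way, so the exchange is expected to give a higher number in this assay, roughly undoing them, as an estimated step of a 4.0-fold higher number from compound 3 to compound 4 (0.61 log units; beyond the scatter). Compound 4 is therefore estimated at 400 nM, within a range of 150 nM to 1200 nM.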

Compound 4, half-maximal inhibitory concentration: 20 nM
Compound 4: middle estimate off by 20-fold (1.30 log units), on the high side; the measured number lies below the stated range.
By their numbers in this assay, from the lowest: compound 4; then compound 3; then compounds 2 and 1 (each within the scatter of the next).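

On the aromatic carbon next to the ring sulfur, 3,4-dimethoxyphenyl gives the lowest number of the four compounds, with a 5.0-fold lower number from compound 3 to compound 4 (0.69 log units; beyond the scatter) and a 14-fold lower number from compound 2 to compound 4 (1.13 log units; beyond the scatter) as well as a 15-fold lower number from compound 1 to compound 4 (1.16 log units; beyond the scatter) and so the three earlier aryl groups did not mark the low end at this position. Their order gave no guide to a methoxy-bearing aryl group. Nothing available here explains this drop.

From the compounds shown here alone, whether a single methoxy group would do as much stays open. So does how an amine, a carboxylic acid or a longer alkoxy chain on this phenyl ring would read.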